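Thiosemicarbazone series: cell growth inhibition on a single cell line

This account rests on a few compounds, and the source may have more. Where it says the series, first, only, none or still open, it means among the compounds named here.

Measured so far:
- compound 1 `Oc1ccc(/C=N\NC(=S)NC2CCCCC2)cc1`: 242000 nM
- compound 2 `S=C(N/N=C\c1cccs1)NC1CCCCC1`: 337000 nM
- compound 3 `CCOc1ccc(/C=N\NC(=S)NC2CCCCC2)cc1`: 252000 nM

In a functional assay on MDA-MB-468 cells (Homo sapiens) for inhibition, read by WST assay, with a stated time of 48 h (a higher number here means a weaker inhibitor, a lower number a stronger inhibitor), compound 1 gives 242000 nM, compound 2 gives 337000 nM and compound 3 gives 252000 nM. Compound 3 stands second highest of the three numbers; its nearest neighbour is compound 1 and its furthest is compound 2, and both gaps lie within the scatter. Within the data shown here, the only single-site step measured, a 1.0-fold higher number from compound 1 to compound 3 (0.02 log units; within the scatter), is within the scatter as well, so nothing measured so far moves the number beyond the noise.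

Compound 4 `CN(C)c1ccc(/C=N\NC(=S)NC2CCCCC2)cc1` is not yet measured. It differs from compound 3 as follows: dimethylamino in place of ethoxy on an aromatic carbon. Among the measured compounds shown here, no measured step covers this exchange; the one step on the same aromatic carbon, a 1.0-fold higher number from compound 1 to compound 3 (0.02 log units; within the scatter), changed nothing beyond the scatter, and the three measured numbers sit together. On that basis no step beyond the scatter is expected in this assay, in either direction, and a 1.0-fold higher number from compound 3 to compound 4 (0.01 log units; within the scatter) is the expected step. Compound 4 is therefore estimated at 260000 nM, with a range from 120000 nM to 550000 nM to allow for the assay scatter at these high concentrations.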

Compound 4, half-maximal inhibitory concentration: 280000 nM
For compound 4 the middle estimate is 1.1-fold (0.03 log units) below the measured one, within the range that was stated.
By their numbers in this assay, from the lowest: compounds 1, 3, 4 and 2 (each within the scatter of the next).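

In this assay, the exchange of ethoxy for dimethylamino on the aromatic carbon gives (a 1.1-fold higher number from compound 3 to compound 4 (0.05 log units; within the scatter)), and the exchange of hydroxy for dimethylamino at the same carbon gives (a 1.2-fold higher number from compound 1 to compound 4 (0.06 log units; within the scatter)). This position has now carried a group joined through nitrogen as well as two joined through oxygen, and neither step leaves the scatter, so within these three compounds the identity of the joining atom has no readable effect on the number, while the exchange from ethoxy to dimethylamino keeps the heavy-atom count and the hydrogen-bond acceptor count as they were. No separate measurement is available to explain this result.

Open, from the compounds shown here alone, is whether any group at this carbon can produce a step beyond the scatter in this assay, for example a carboxylic acid, a primary amine, a halogen such as chlorine or a longer alkoxy chain. Also open, going by these compounds, is whether a change elsewhere on the shared core, rather than on this aromatic carbon, would move the number at all.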